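The compounds below may be only part of what the source reports. "The series", "measured", "known", "first", "only" and "open" are said of these compounds alone.

Three compounds have been measured in a functional assay on Mahlavu cells (Homo sapiens) for antiproliferative activity, read by sulforhodamine B assay, with a stated time of 72 h; a lower number here means a stronger inhibitor, a higher number a weaker inhibitor:

compound 1, `Cc1ccccc1COc1ccc(-c2cc(CN3CCN(Cc4ccc(C(F)(F)F)cc4)CC3)no2)cc1`, gives 6800 nM;
compound 2, `Cc1ccc(COc2ccc(-c3cc(CN4CCN(Cc5ccc(C(F)(F)F)cc5)CC4)no3)cc2)cc1`, gives 7500 nM;
compound 3, `FC(F)(F)c1ccc(CN2CCN(Cc3cc(-c4ccc(OCc5ccccc5Cl)cc4)on3)CC2)cc1`, gives 3200 nM.

Compound 3 holds the lowest number of the three: the step of a 2.1-fold lower number from compound 1 to compound 3 (0.33 log units; beyond the scatter) and the step of a 2.3-fold lower number from compound 2 to compound 3 (0.37 log units; beyond the scatter) both run beyond the scatter, though only modestly. Compound 4, `N#Cc1ccc(COc2ccc(-c3cc(CN4CCN(Cc5ccc(C(F)(F)F)cc5)CC4)no3)cc2)cc1`, has not yet been measured. It differs from compound 3 in one place: 4-cyanophenyl in place of 2-chlorophenyl on a saturated chain carbon bound to an oxygen on an aromatic ring. Two of the measured steps bear on this change. The exchange of a 2-methylphenyl for a 4-methylphenyl group, a 1.1-fold higher number from compound 1 to compound 2 (0.04 log units; within the scatter), stayed within the scatter, so swapping a 2-substituted for a 4-substituted phenyl group has so far changed little. The lower number of compound 3 arrived together with the chloro group, as the step of a 2.1-fold lower number from compound 1 to compound 3 (0.33 log units; beyond the scatter) shows, and compound 4 gives that group up. Within the data shown here, no measured compound carries a nitrile, so nothing is known here about that group. The number for compound 4 is therefore expected to drift back toward those of compound 1 and compound 2. The expected step is about a 1.6-fold higher number from compound 3 to compound 4 (0.19 log units; within the scatter), with wide uncertainty. The estimate for compound 4 in this assay is 5000 nM, within a range from 2500 nM to 11000 nM.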

Compound 4, half-maximal inhibitory concentration: 4300 nM
The estimate for compound 4 lay 1.2-fold (0.07 log units) above the measured number; the range from low to high includes it.
By their numbers in this assay, from the lowest: compounds 3, 4, 1 and 2 (each within the scatter of the next, the first and the last beyond it).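

In this assay, the change from 2-chlorophenyl to 4-cyanophenyl on a saturated chain carbon bound to an oxygen on an aromatic ring stays within the scatter (a 1.3-fold higher number from compound 3 to compound 4 (0.13 log units; within the scatter)), so at this position a nitrile gives a number that cannot be told apart from that of the chloro compound. The same holds against both methyl compounds (a 1.7-fold lower number from compound 2 to compound 4 (0.24 log units; within the scatter); a 1.6-fold lower number from compound 1 to compound 4 (0.20 log units; within the scatter)), and compound 4 therefore cannot be separated from any of the other three, even though compound 3 stands beyond the scatter of compound 1 and compound 2. The measured numbers give no reason for this outcome.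

The step from 2-chlorophenyl to 4-cyanophenyl changes both the group and the number in its name, so these compounds do not show which of the two matters, or whether the lower number of compound 3 belongs to the chloro group itself. Also open, on these data alone, is what an amine or a carboxylic acid on the phenyl ring, or a longer chain between the oxygen and that ring, would do to the number.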